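A few compounds are considered here, and "the series" means these few. Any claim that something is new, unique, unknown or untested is made for them only; others in the source may bear on it.

Measured so far in a functional assay on HCT-116 cells (Homo sapiens) for antiproliferative activity, read by MTT assay, with a stated time of 48 h; a lower number here means a stronger inhibitor, a higher number a weaker inhibitor:
- compound 1 `Cc1ccc2nc(Nc3nc(Nc4ccc(S(N)(=O)=O)cc4)ncc3F)sc2c1`: 1460 nM
- compound 2 `Cc1ccc2nc(Nc3nc(Nc4ccc(S(N)(=O)=O)cc4)ncc3C)sc2c1`: 3870 nM
- compound 3 `Cc1ccc2nc(Nc3ccnc(Nc4ccc(S(N)(=O)=O)cc4)n3)sc2c1`: 900 nM

Compound 2 stands highest of the three: compound 1 is nearest, with a 2.7-fold higher number from compound 1 to compound 2 (0.42 log units; beyond the scatter) separating them, and compound 3 furthest, with a 4.3-fold lower number from compound 2 to compound 3 (0.63 log units; beyond the scatter). Between compound 1 and compound 3 the step is a 1.6-fold lower number from compound 1 to compound 3 (0.21 log units; within the scatter).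

Compound 4 `Cc1cnc(Nc2ccc(S(N)(=O)=O)cc2)nc1Nc1nc2ccc(F)cc2s1` differs from compound 2 by fluoro in place of methyl on an aromatic carbon. Among the measured compounds shown here, none of the measured steps touches this position: all three sit at a different place on the shared core. The step from compound 1 to compound 2 involves the same pair of groups, methyl against fluoro, and was modest, but at another position it gives only loose guidance. A step of modest size at most is therefore expected in this assay, with a lower number somewhat more likely than a higher one. Compound 4 is expected to give 2500 nM (range 1000 nM to 6000 nM). The expected step is a 1.5-fold lower number from compound 2 to compound 4 (0.19 log units; within the scatter).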

Compound 4, half-maximal inhibitory concentration: 2010 nM
Compound 4: middle estimate off by 1.2-fold (0.09 log units), on the high side, within the range that was stated.
By their numbers in this assay, from the lowest: compounds 3, 1, 4 and 2 (each within the scatter of the next, the first and the last beyond it).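

In this assay, fluoro in place of methyl on this aromatic carbon, on the six-membered aromatic ring of carbon only, gives a 1.9-fold lower number from compound 2 to compound 4 (0.28 log units; within the scatter), so the two groups are not told apart at this position. At the other place on the shared core the same pair of groups is told apart, with methyl in place of fluoro giving a 2.7-fold higher number from compound 1 to compound 2 (0.42 log units; beyond the scatter), so the reading for this pair does not carry over from one position to the other. No measured evidence at hand bears on what lies behind this result.

Open, on these data alone, is how an amine, a methoxy or a carboxylic acid on this aromatic carbon would read in this assay. Also open, as far as these compounds go, is whether fluoro and methyl stay this close here in any other cell line or read-out.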